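Swapping Methyl for Fluoro on Compound 3

The compounds below may be only part of what the source reports. "The series", "measured", "known", "first", "only" and "open" are said of these compounds alone.

In a functional assay on HCT-116 cells (Homo sapiens) for inhibition, read by MTT assay, with a stated time of 48 h (a higher number here means a weaker inhibitor, a lower number a stronger inhibitor), compound 3 `COc1cc(-c2nnc(SCc3ccc(C)cc3)n2-c2ccc(N(C)C)cc2)cc(OC)c1OC` gives > 60000 nM, which is a limit of the assay and not a number. Compound 2 `COc1cc(-c2nnc(SC)n2-c2ccc(N(C)C)cc2)cc(OC)c1OC` gives > 60000 nM, also a limit. Among the compounds with values here, the one measured step nearby is a step that the two limits leave unreadable from compound 2 to compound 3, so it offers no size to build on.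

Compound 4 `COc1cc(-c2nnc(SCc3ccc(F)cc3)n2-c2ccc(N(C)C)cc2)cc(OC)c1OC` comes from compound 3 by a single exchange, (fluoro in place of methyl on an aromatic carbon). Compound 1 `COc1ccc(-n2c(SCc3ccc(F)cc3)nnc2-c2cc(OC)c(OC)c(OC)c2)cc1` also carries (4-fluorobenzyl)sulfanyl but differs elsewhere, and it gives 38700 nM, so a result for compound 4 not far from that number is expected. Within the data shown here, no step of known size or direction can be drawn from this assay, and the expected change is only loosely held: an at least 1.2-fold lower number from compound 3 to compound 4 (0.07 log units; that floor lies within the scatter). For compound 4 the estimate is 50000 nM, with an expected range of 25000 nM to 100000 nM.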

Compound 4, half-maximal inhibitory concentration: > 60000 nM
Compound 4 was reported as a limit (the forecaster's own chance of this, stated with the estimate: 60%); middle value at least 1.2-fold (0.07 log units) from the limit.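

Fluoro in place of methyl at this position leaves the compound at the ceiling of this assay, so neither that exchange nor the steps from the smaller methyl sulfide can be read: the limit of > 60000 nM in this assay, at which 3 of the 4 values shown sit. Within the data shown here, the one readable step, dimethylamino in place of methoxy on an aromatic carbon, is an at least 1.5-fold higher number from compound 1 to compound 4 (0.19 log units; that floor lies within the scatter), so it cannot yet be said that this exchange matters. (4-Fluorobenzyl)sulfanyl alone therefore does not bring a dimethylamino compound into the readable range.

On these data alone, whether a chloro or a carboxylic acid at this position would give a readable number stays open.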